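A few compounds are considered here, and "the series" means these few. Any claim that something is new, unique, unknown or untested is made for them only; others in the source may bear on it.

For the measured compounds named here, compound 1 `COc1ccccc1/C=c1\c(=O)[nH]/c(=C/c2cccc(Cl)c2Cl)c(=O)n1C` gives 110 nM in a functional assay on K562 cells (Homo sapiens) for cytotoxicity, read by CCK-8 assay, with a stated time of 72 h (a lower number here means a stronger inhibitor, a higher number a weaker inhibitor), the lower of the two numbers measured so far. Compound 2 `C=CCn1c(=O)/c(=C\c2cc(F)ccc2C)[nH]c(=O)/c1=C\c1ccccc1OC` gives 1800 nM in this assay, and the gap between compound 2 and compound 1 lies beyond the usual scatter. Compound 3 `COc1ccccc1/C=c1/[nH]c(=O)/c(=C\c2ccccc2OC)n(C)c1=O` has not yet been measured; it differs from compound 1 by 2-methoxyphenyl in place of 2,3-dichlorophenyl on a double-bonded chain carbon bound to an aromatic carbon. Going by the values given here, no pair of measured compounds shows this change, so its direction is uncertain; in this assay a modest move toward a higher number is expected, a 4.1-fold higher number from compound 1 to compound 3 (0.61 log units; beyond the scatter). Compound 3 is therefore estimated at 450 nM, within a range from 120 nM to 2500 nM.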

Compound 3, half-maximal inhibitory concentration: 2200 nM
Compound 3: middle estimate off by 4.9-fold (0.69 log units), on the low side; low and high end bracket the measured number.
By their numbers in this assay, from the lowest: compound 1; then compounds 2 and 3 (each within the scatter of the next).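

For the compounds shown here, this is the first change at a single position that can be read: on a double-bonded chain carbon bound to an aromatic carbon, 2-methoxyphenyl in place of 2,3-dichlorophenyl gives a 20-fold higher number from compound 1 to compound 3 (1.30 log units; beyond the scatter) in this assay. The rest of the molecule stays the same, so this position clearly matters for the number. Nothing available explains the size of this step.

As far as these compounds go, the swap removes the chlorine atoms and adds the methoxy group in one move, so their separate contributions stay unknown. From the compounds shown here alone, how a plain phenyl or an aminophenyl group would behave at this position also remains open.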